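From 2,3-dichlorophenyl to 2,3,4-trimethoxyphenyl: working notes

The source may report more compounds than this note shows. Statements on the series, on what has been measured and on what is new or still open speak of the compounds shown alone.

Of the compounds shown here, two have numbers so far in a functional assay on PC-3 cells (Homo sapiens) for cytotoxicity, read by MTT assay, with a stated time of 72 h; a higher number here means a weaker inhibitor, a lower number a stronger inhibitor. Compound 1 `O=C(N/N=C/c1cccc(Br)c1)Nc1cc2c(Nc3ccc(F)c(Cl)c3)ncnc2cc1O[C@H]1CCOC1` gives 15500 nM. Compound 2 `O=C(N/N=C/c1cccc(Cl)c1Cl)Nc1cc2c(Nc3ccc(F)c(Cl)c3)ncnc2cc1O[C@H]1CCOC1` gives 27400 nM, which places it level with compound 1 within the scatter. Among the measured compounds shown here, the only measured step is a 1.8-fold higher number from compound 1 to compound 2 (0.25 log units; within the scatter), with 2,3-dichlorophenyl in place of 3-bromophenyl on a carbon with a double bond to nitrogen.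

Compound 3 `COc1ccc(/C=N/NC(=O)Nc2cc3c(Nc4ccc(F)c(Cl)c4)ncnc3cc2O[C@H]2CCOC2)c(OC)c1OC` keeps the shared core and differs from compound 2 at that same place: 2,3,4-trimethoxyphenyl in place of 2,3-dichlorophenyl on a carbon with a double bond to nitrogen. For the measured compounds named here, the one measured step bears on this change only loosely. Going by the values given here, it exchanges one halogen-bearing phenyl for another, and no measured compound carries a methoxy group.

Among the compounds with values here, with compound 2 at 27400 nM as the anchor and a 1.8-fold higher number from compound 1 to compound 2 (0.25 log units; within the scatter) as the sole guide, no shift beyond the scatter is expected in this assay, in either direction. The expected step is a 1.4-fold lower number from compound 2 to compound 3 (0.14 log units; within the scatter). For compound 3 the estimate is 20000 nM, with an expected range of 8000 nM to 50000 nM.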

Compound 3, half-maximal inhibitory concentration: 25600 nM
The estimate for compound 3 lay 1.3-fold (0.11 log units) below the measured number, within the range that was stated.
By their numbers in this assay, from the lowest: compounds 1, 3 and 2 (each within the scatter of the next).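

In this assay, among the compounds shown here, the place on a carbon with a double bond to nitrogen now holds a phenyl without halogen as well as two halogen-bearing phenyls, and no step among the three lies beyond the scatter: the direct exchange gives a 1.1-fold lower number from compound 2 to compound 3 (0.03 log units; within the scatter) and the comparison with the bromo compound gives a 1.7-fold higher number from compound 1 to compound 3 (0.22 log units; within the scatter) as the second reading. The earlier step swapped only one halogen-bearing phenyl for another, whereas 2,3,4-trimethoxyphenyl replaces both chlorine atoms with three methoxy groups, bringing 12 heavy atoms in place of 8 and 3 hydrogen-bond acceptors in place of 0, and still the number does not move beyond the scatter. Nothing measured on these compounds beyond this read-out is available to account for that level reading.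

As far as these compounds go, all three compounds carry a substituted phenyl at this place, so it remains open whether a basic amine such as a dimethylaminophenyl, a carboxylic acid or a saturated ring in its stead would shift the number beyond the scatter. From the compounds shown here alone, it also remains open whether a single methoxy or hydroxyl group on the phenyl would read the same as the three methoxy groups.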